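A few compounds are considered here, and "the series" means these few. Any claim that something is new, unique, unknown or untested is made for them only; others in the source may bear on it.

Compound 2 `Cc1ccc2[nH]c(=O)c(/C=N/O)cc2c1` gives 38900 nM in a functional assay, read by spectrophotometry, with a stated time of 3 min (a lower number here means a stronger inhibitor, a higher number a weaker inhibitor), the highest of the three numbers measured. Compound 3 `O=c1[nH]c2ccccc2cc1/C=N/O` stands nearest to it with 31800 nM; compound 1 `O=c1[nH]c2ccccc2cc1/C=N/c1ccccc1O`, with 11700 nM, lies furthest away and beyond the scatter. Going by the values given here, the one single-point step in the set, a 1.2-fold lower number from compound 2 to compound 3 (0.09 log units; within the scatter), concerns hydrogen in place of methyl on an aromatic carbon and has no bearing on the change now considered. Compound 4 `Cc1ccc2[nH]c(=O)c(/C=N/N)cc2c1` differs from compound 2 by amino in place of hydroxy on a double-bonded nitrogen. Among the compounds with values here, no measured pair tests an exchange on the double-bonded nitrogen, so the step is expected to stay within the scatter, a 1.1-fold lower number from compound 2 to compound 4 (0.05 log units; within the scatter). Compound 4 is therefore estimated at 35000 nM, with a range of 12000 nM to 100000 nM.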

Compound 4, half-maximal inhibitory concentration: 11300 nM
Beside the measured number, compound 4's estimate is 3.1-fold (0.49 log units) above it; measured number outside the range, below it.
By their numbers in this assay, from the lowest: compounds 4 and 1 (each within the scatter of the next); then compounds 3 and 2 (each within the scatter of the next).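

Going by these compounds alone, on a double-bonded nitrogen, amino in place of hydroxy brings a 3.4-fold lower number from compound 2 to compound 4 (0.54 log units; beyond the scatter) in this assay, the first evidence that this position responds to an exchange. The step occurs with no change in heavy-atom count, hydrogen-bond donors, hydrogen-bond acceptors or net charge between the leaving and entering groups. Nothing available explains the step. Going by these compounds, whether methoxy or dimethylamino on the same nitrogen would shift the number remains open. Also open, on these data alone, is whether amino has a similar effect on the core of compound 3, which lacks the methyl.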